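This account rests on a few compounds, and the source may have more. Where it says the series, first, only, none or still open, it means among the compounds named here.

Measured compounds:
compound 1 `Cc1n[nH]c(C(=O)O)c1Cc1ccc(Oc2ccccc2)cc1` — 10%
compound 2 `Cc1n[nH]c(C(=O)O)c1Cc1ccc2ccccc2n1` — 2%

Both compounds share the same core and were tested in an assay on isolated protein for inhibition of 2-Hydroxyacid oxidase 2 (Homo sapiens), tested at 1 uM; on this read-out higher numbers stand for a stronger effect at the one concentration tested and lower numbers for a weaker effect. In this assay compound 1 gives 10%, and compound 2 gives 2%. The gap between these two readings lies within the usual scatter of the measurement, so neither compound stands apart from the other; both readings are small. Within the data shown here, no pair among them differs in only one place, so no single step between measured compounds can be drawn from these numbers.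

Compound 3 `Cc1n[nH]c(C(=O)O)c1Cc1ccc(-c2ccc(F)cc2)cc1` has not yet been measured. It differs from compound 1 by 4-fluorophenyl in place of phenoxy on an aromatic carbon. Nothing in the measured pair tells how this change acts on the read-out. Since compound 1 itself gives only 10%, there is little room for a fall, and the sole other data point, compound 2, gives 2%, another small reading. The step of no change at the digits printed from compound 1 to compound 3 (within the scatter) is therefore expected to lie within the scatter, in no clear direction. Compound 3 is expected to give about 10% in this assay, with a range from 0% to 30%.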

Compound 3, a percentage reported as inhibition, at one concentration (the size of the read-out at that concentration, not a potency): 11%
Estimate against measurement, compound 3: 1 percentage points below; the range from low to high includes it.
By their numbers in this assay, from the lowest: compounds 2, 1 and 3 (each within the scatter of the next).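

In this assay, among these compounds, the exchange of phenoxy for 4-fluorophenyl on an aromatic carbon, para to a large group, gives the first step that can be read at this position: a number 1 percentage points higher from compound 1 to compound 3 (within the scatter). The exchange removes the oxygen of phenoxy, with its hydrogen-bond acceptor, and brings in a fluorine on a ring of the same kind, with the same number of heavy atoms, yet the two readings stay within the scatter of each other, so at the one concentration tested the oxygen is not required for a reading of this size. No measured evidence on the reason for this result is available.

On these data alone, both readings are small, so this single step does not show whether any group at this position can give a clearly stronger effect, and an amine, a carboxylic acid or a longer alkyl chain in place of 4-fluorophenyl remains open. The part played by the fluorine also remains open, since the compounds shown include no plain phenyl at this position for comparison with compound 3.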